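Ring-nitrogen substituent change in the shared core

This account rests on a few compounds, and the source may have more. Where it says the series, first, only, none or still open, it means among the compounds named here.

For the measured compounds named here, compound 2 `CC(C)(C)COC(=O)N1CCC(Oc2ncnc3c2CCN3c2ccc(S(C)(=O)=O)cc2F)CC1` gives 39.8 nM in a functional assay on CHO-K1 cells for agonist activity at Glucose-dependent insulinotropic receptor (Homo sapiens), read by a luciferase reporter, with a stated time of 5 h (a lower number here means that less compound is needed, a higher number that more compound is needed for the effect), and stands at the lower of the two numbers so far, though the gap to compound 1 `CC(C)OC(=O)N1CCC(Oc2ncnc3c2CCN3c2ccc(C#N)cc2F)CC1`, which gives 63.1 nM in this assay, is within the scatter. Compound 3 `CC(C)c1noc(N2CCC(Oc3ncnc4c3CCN4c3ccc(S(C)(=O)=O)cc3F)CC2)n1` differs from compound 2 by 3-isopropyl-1,2,4-oxadiazol-5-yl in place of neopentyloxycarbonyl on an amine nitrogen in a ring. Going by the values given here, no step between measured compounds covers this change, so the expectation rests only on compound 2 at 39.8 nM and on the size of the change. The step of a 1.3-fold lower number from compound 2 to compound 3 (0.12 log units; within the scatter) is expected to be small, with a slight lean downward, and likely not beyond the scatter. Compound 3 is estimated at 30 nM, within a range of 10 nM to 100 nM.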

Compound 3, half-maximal effective concentration: 79.4 nM
Estimate against measurement, compound 3: 2.6-fold (0.42 log units) below; the range from low to high includes it.
By their numbers in this assay, from the lowest: compounds 2, 1 and 3 (each within the scatter of the next).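

On the amine nitrogen in the ring, 3-isopropyl-1,2,4-oxadiazol-5-yl replaces neopentyloxycarbonyl with a 2.0-fold higher number from compound 2 to compound 3 (0.30 log units; within the scatter) as the step, so this position accepts a five-membered aromatic ring as well as an open chain. The carbonyl of neopentyloxycarbonyl is therefore not needed for activity in this range. No measurement available here accounts for the result.

Still open, as far as these compounds go, is how a tert-butyl or cyclopropyl group would read in place of the isopropyl on the oxadiazole. From the compounds shown here alone, a simple amide or a pyrimidin-2-yl ring on the same nitrogen also remains untested in these compounds.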